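Indole-bearing pyran series: aryl change at the saturated carbon

A few compounds are considered here, and "the series" means these few. Any claim that something is new, unique, unknown or untested is made for them only; others in the source may bear on it.

- compound 1 `N#CC1=C(N)OC(c2c[nH]c3ccccc23)=C(C#N)C1c1ccccc1F`: "not active" (no number reported), reported without a number, no effect found
- compound 2 `N#CC1=C(N)OC(c2c[nH]c3ccccc23)=C(C#N)C1c1ccc2ccccc2c1`: "not active" (no number reported), reported without a number, no effect found
- compound 3 `N#CC1=C(N)OC(c2c[nH]c3ccccc23)=C(C#N)C1c1cccc2ccccc12`: 7.7%

Three compounds of the shared core have been run in a functional assay, tested at 200 ug/mL; on this read-out higher numbers stand for a stronger effect at the one concentration tested and lower numbers for a weaker effect. Within the data shown here, compound 3 is the only one with a number; in this assay compound 3 gives 7.7%, a weak effect at the single concentration tested. In this assay, among the measured compounds shown here, compound 1 is reported as "not active" (no number reported) and compound 2 is reported as "not active" (no number reported), each with no number attached, so no step between measured compounds can be stated here.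

Compound 4 `N#CC1=C(N)OC(c2c[nH]c3ccccc23)=C(C#N)C1c1ccccc1` is the next entry and remains to be measured in this assay. Against compound 3 the change is phenyl in place of naphthalen-1-yl on a saturated ring carbon.

For the measured compounds named here, nothing measured separates a naphthalen-1-yl from a phenyl at this position, and the one number in hand already sits low. The expected step from compound 3 to compound 4 in this assay is therefore a number 1.7 percentage points lower from compound 3 to compound 4 (within the scatter), which is nothing beyond the scatter. Compound 4 is estimated to give 6% in this assay, within a range from 0% to 18%.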

Compound 4, a percentage reported as activity, at one concentration (the size of the read-out at that concentration, not a potency): 24.5%
Compound 4: the middle estimate sits 18.5 percentage points below what was measured; measured number above the stated range.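

In this assay, among these compounds, the aryl group on this saturated ring carbon matters: phenyl in place of naphthalen-1-yl gives a number 16.8 percentage points higher from compound 3 to compound 4 (beyond the scatter) and provides the first readable step. The change removes one of the two six-membered aromatic rings of carbon only, and for this pair the single-ring group gives the stronger effect, although the step is modest and rests on one concentration. Nothing measured here explains the step.

Steps involving compound 1 and compound 2 cannot be read: both are reported without a number. Still open, on these data alone, is whether a phenyl carrying a methoxy group or an amine, or a saturated cyclohexyl group on this carbon, would hold or raise the effect seen with compound 4.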